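Swapping the anilino for 3-chlorophenyl on the carbonyl

The source may hold more compounds than are shown below. What is called first, only, known or untested is meant among the compounds shown, and "the series" means these compounds.

Measured compounds:
- compound 1, `CC1=CC[C@H](C(C)C)c2cc(C)c(OC(=O)Nc3ccccc3)cc21`: 100%
- compound 2, `COc1cccc(C(=O)Oc2cc3c(C)ccc(C(C)C)c3cc2C)c1`: "not active" (no number reported)
- compound 3, `CC1=CC[C@H](C(C)C)c2cc(C)c(OC(=O)c3ccc(C(F)(F)F)cc3)cc21`: 14.7%

In a functional assay on U-251 cells (Homo sapiens) for antiproliferative activity, read by sulforhodamine B assay, with a stated time of 48 h, tested at 50 uM (on this read-out higher numbers stand for more inhibition at the one concentration tested (going by the name of the read-out) and lower numbers for less inhibition), compound 1 gives 100%, the highest of the two numbers reported. Its nearest neighbour is compound 3, which in this assay gives 14.7%, a difference beyond the scatter. Compound 2 carries a differently arranged core; in this assay compound 2 is reported as "not active" (no number reported), with no number attached.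

Compound 4, `CC1=CC[C@H](C(C)C)c2cc(C)c(OC(=O)c3cccc(Cl)c3)cc21`, keeps the core of compound 1 and changes only the group on the carbonyl carbon: 3-chlorophenyl in place of anilino on a carbonyl carbon. Within the data shown here, no measured pair differs in exactly this way, so the size of the step must be judged from what the other compounds show. Compound 3 carries an aromatic carbon ring on the same carbonyl carbon, and compound 3 gives 14.7%, far below compound 1, while compound 2, also with an aromatic ring on the carbonyl, gives "not active" (no number reported).

On that basis the step of a number 75 percentage points lower from compound 1 to compound 4 (beyond the scatter) is expected to be a large fall, well beyond the scatter. Compound 4 is therefore estimated at 25%, within a range from 0% to 60%, because compound 3 gives 14.7%.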

Compound 4, a percentage reported as inhibition, at one concentration (the size of the read-out at that concentration, not a potency): 0.9%
Compound 4: middle estimate off by 24.1 percentage points, on the high side, and the stated range covers the measured number.
By their numbers in this assay, from the lowest: compound 4; then compound 3; then compound 1.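

Among these compounds, replacing anilino with 3-chlorophenyl on the carbonyl carbon gives, in this assay, a number 99.1 percentage points lower from compound 1 to compound 4 (beyond the scatter), and this is the first measured pair in which the change is confined to one place. Among the compounds shown here, the high value of compound 1 can therefore be tied to this position, which the earlier compounds could not show. The size of the fall is notable given how much the two groups share: they match in heavy-atom count and in their six-membered aromatic ring of carbon only, while anilino holds nitrogen and a hydrogen-bond donor and 3-chlorophenyl holds chlorine and no donor. Nothing measured here explains why the step is so large.

For the compounds shown here, with only this pair, the nitrogen and the chlorine cannot be separated, so 3-chloroanilino on the same carbonyl carbon would be the telling group. From the compounds shown here alone, it also remains open whether a methylated anilino, a benzylamino group or a cyclohexylamino group at this place would stay near compound 1 or fall towards compound 4 .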